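This account rests on a few compounds, and the source may have more. Where it says the series, first, only, none or still open, it means among the compounds named here.

In a functional assay on SW 1116 cells (Homo sapiens) for antiproliferative activity, read by MTT assay, with a stated time of 24 h (on this read-out lower numbers stand for stronger inhibition and higher numbers for weaker inhibition), compound 1 (`Sc1nnc(-c2ccc3c(c2)OCCO3)n1-c1ccccc1`), with hydrogen on the sulfur, gives 38400 nM as its value. Compound 2 (`Clc1ccccc1CSc1nnc(-c2ccc3c(c2)OCCO3)n1-c1ccccc1`) reads 9670 nM and compound 3 (`COc1cccc(CSc2nnc(-c3ccc4c(c3)OCCO4)n2-c2ccccc2)c1`) reads 10100 nM on the same measure. Compound 3 thus stands level with compound 2 and well under compound 1. The modest steps of a 4.0-fold lower number from compound 1 to compound 2 (0.60 log units; beyond the scatter) and a 3.8-fold lower number from compound 1 to compound 3 (0.58 log units; beyond the scatter) came with the benzyl groups, while a 1.0-fold higher number from compound 2 to compound 3 (0.02 log units; within the scatter) lies within the scatter. Next is compound 4 (`Cc1ccc(CSc2nnc(-c3ccc4c(c3)OCCO4)n2-c2ccccc2)cc1`), where the change is 4-methylphenyl in place of 3-methoxyphenyl on a saturated chain carbon bound to a sulfur with 4-methylphenyl in place of 3-methoxyphenyl on a saturated chain carbon bound to a sulfur. Within the data shown here, the one measured swap at this place stayed within the scatter, so this assay is expected to show no step beyond it. The expected step runs a 1.0-fold lower number from compound 3 to compound 4 (0.00 log units; within the scatter) by this estimate. For compound 4 the estimated value is 10000 nM with an expected range of 5000 nM to 20000 nM on this measure.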

Compound 4, half-maximal inhibitory concentration: 16200 nM
Compound 4: middle estimate off by 1.6-fold (0.21 log units), on the low side, within the range that was stated.
By their numbers in this assay, from the lowest: compounds 2, 3 and 4 (each within the scatter of the next); then compound 1.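

In this assay, a third substituted phenyl on the saturated chain carbon bound to a sulfur stays within the scatter of the other two, even without a hydrogen-bond acceptor in the group (a 1.6-fold higher number from compound 3 to compound 4 (0.21 log units; within the scatter); a 1.7-fold higher number from compound 2 to compound 4 (0.22 log units; within the scatter)). The step from hydrogen on the sulfur now also holds for 4-methylbenzyl (a 2.4-fold lower number from compound 1 to compound 4 (0.37 log units; beyond the scatter)), so it is beyond the scatter for all three benzyl groups. No measurement on hand explains why these three groups read alike. Open, from the compounds shown here alone, is whether an amine, a carboxylic acid or a longer chain on the sulfur would move the number beyond the scatter.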